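Solubility at low pH across a small acid series

The source may report more compounds than this note shows. Statements on the series, on what has been measured and on what is new or still open speak of the compounds shown alone.

Measured so far:
compound 1 `CCCN(Cc1ccc(OCCN2C(=O)CCC2=O)c(C)c1)[C@@H](CC(=O)O)c1ccc(Cl)cc1`, 3000000 nM
compound 2 `Cc1cc(CN(CC2CC2)[C@@H](CC(=O)O)c2ccc(Cl)cc2)ccc1OCCN1C(=O)CCC1=O`, 3000000 nM
compound 3 `CCCN(Cc1ccc(OCCn2c(=O)ccn(C)c2=O)c(C)c1)C(CC(=O)O)c1ccc(Cl)cc1`, 3000000 nM

In a physicochemical assay for solubility, at pH 1.1 (on this read-out lower numbers stand for lower solubility and higher numbers for higher solubility), compound 1 gives 3000000 nM. The step of no change at the digits printed from compound 1 to compound 2 (within the scatter) belongs to the change (cyclopropyl in place of ethyl on a saturated chain carbon bound to an amine nitrogen). Compound 3 gives 3000000 nM in this assay; the difference between its core and the core of compound 1 is not broken down here. Compound 4 `Cc1cc(CN(CC2CC2)C(CC(=O)O)c2ccc(Cl)cc2)ccc1OCCn1c(=O)ccn(C)c1=O` is not yet measured and differs from compound 3 by cyclopropyl in place of ethyl on a saturated chain carbon bound to an amine nitrogen, the same change, at the same place, as that from compound 1 to compound 2. Because no change at the digits printed from compound 1 to compound 2 (within the scatter) showed no shift, the step from compound 3 to compound 4 in this assay is expected to be no change at the digits printed from compound 3 to compound 4 (within the scatter). Compound 4 is accordingly estimated at 3000000 nM, with a range from 1500000 nM to 6000000 nM.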

Compound 4, solubility: 3000000 nM
Estimate against measurement, compound 4: no gap at the digits printed, within the range that was stated.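

In this assay, cyclopropyl in place of ethyl on a saturated chain carbon bound to an amine nitrogen gives no change at the digits printed from compound 3 to compound 4 (within the scatter) and, on the core of compound 1, gives no change at the digits printed from compound 1 to compound 2 (within the scatter) as well, so the step reads the same on both cores. These two pairs show that agreement only and do not show that it extends to any further core or to any other read-out. Nothing available here accounts for the result.

The compounds shown leave open how butyl or cyclobutyl on a saturated chain carbon bound to an amine nitrogen would read in this assay on either core.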